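Notes on the aryl group: from compound 3 to compound 4

A few compounds are considered here, and "the series" means these few. Any claim that something is new, unique, unknown or untested is made for them only; others in the source may bear on it.

Measured compounds in an in vitro assay on HEK385-7 cells for displacement of a labelled ligand from prostaglandin D2 receptor 2 (Homo sapiens); on this read-out lower numbers stand for stronger inhibition and higher numbers for weaker inhibition:
compound 1 `O=C(O)Cc1sc(C(c2ccccc2)c2ccccc2)nc1-c1ccccc1`, 570 nM
compound 2 `O=C(O)Cc1sc(C(c2ccc(F)cc2)c2ccc(F)cc2)nc1-c1ccnc(N2CCC2)c1`, 660 nM
compound 3 `NS(=O)(=O)c1cccc(-c2nc(C(c3ccc(F)cc3)c3ccc(F)cc3)sc2CC(=O)O)c1`, 140 nM

Compound 3 holds the lowest of the three numbers in this assay. Compound 1 gives 570 nM and compound 2 gives 660 nM; both stand beyond the scatter above compound 3, and the gap to compound 2 is the wider one. Among the compounds with values here, compound 1 differs from compound 3 in more than one place, so only the pair compound 2 and compound 3 forms a single step.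

The unmeasured compound 4 is `Cc1cc(-c2nc(C(c3ccc(F)cc3)c3ccc(F)cc3)sc2CC(=O)O)ccn1`. Relative to compound 3 the change is 2-methylpyridin-4-yl in place of 3-sulfamoylphenyl on an aromatic carbon.

Within the data shown here, the one step that bears on this is a 4.7-fold lower number from compound 2 to compound 3 (0.67 log units; beyond the scatter). It moves from a pyridinyl-bearing compound to the 3-sulfamoylphenyl compound; the present change runs the other way, with 2-methylpyridin-4-yl entering in place of 3-sulfamoylphenyl, though the pyridinyl now carries a methyl rather than the azetidinyl seen in compound 2. Compound 1, without the sulfamoyl group, also sits at a higher number. Among the measured compounds shown here, a rise beyond the scatter is therefore expected, probably somewhat short of a full reversal of that step, since the entering group is not the one of compound 2.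

Compound 4 is expected to give about 420 nM in this assay, within 150 nM to 1200 nM, a step of a 3.0-fold higher number from compound 3 to compound 4 (0.48 log units; beyond the scatter).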

Compound 4, half-maximal inhibitory concentration: 3.1 nM
Beside the measured number, compound 4's estimate is 140-fold (2.13 log units) above it, outside the stated range (below it).
By their numbers in this assay, from the lowest: compound 4; then compound 3; then compounds 1 and 2 (each within the scatter of the next).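

At the aromatic carbon next to the ring nitrogen, a 45-fold lower number from compound 3 to compound 4 (1.65 log units; beyond the scatter) in this assay shows that the 3-sulfamoylphenyl group does not set the floor for this series, since 2-methylpyridin-4-yl goes far lower with fewer heavy atoms and no hydrogen-bond donor. The pyridinyl group alone does not fix the number either, as a 210-fold lower number from compound 2 to compound 4 (2.33 log units; beyond the scatter) comes from methyl in place of azetidin-1-yl, so the group carried on that ring counts heavily at this position. Nothing shown here accounts for either step.

Open, from the compounds shown here alone, is whether the methyl group itself is needed, which a plain pyridin-4-yl or an ethyl, methoxy or chloro group in its place would test. Also open, going by these compounds, is what the ring nitrogen contributes, which a methylphenyl group at the same aromatic carbon would separate from the contribution of the methyl group.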